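Swapping a Simple Amide for a Hydroxamate on the Shared Core

The source may hold more compounds than are shown below. What is called first, only, known or untested is meant among the compounds shown, and "the series" means these compounds.

Compound 1 `COc1ccc(NC(=O)[C@@H]2CC=C(CCC=C(C)C)C[C@H]2c2ccccc2)cc1`, compound 2 `CC(C)=CCCC1=CC[C@H](C(=O)N(C)O)[C@@H](c2ccccc2)C1` and compound 3 `CC(C)=CCCC1=CC[C@@H](C(N)=O)[C@H](c2ccccc2)C1` share one core and differ in the group attached to the carbonyl carbon. In an assay on isolated protein for inhibition of Apoptosis regulator Bcl-2 (Homo sapiens), read by fluorescence polarization, with stated times of 5 min and 10 min (on this read-out lower numbers stand for stronger inhibition and higher numbers for weaker inhibition), compound 1 gives only a limit, > 23000 nM. In this assay compound 3 likewise gives only a limit, > 23000 nM. The change from compound 1 to compound 3 therefore reads as a step that the two limits leave unreadable from compound 1 to compound 3. In this assay compound 2 gives 2100 nM, a readable number. Compound 3 thus sits at the limit of > 23000 nM in this assay, at which 2 of the 3 values shown sit, so no number places it among the others.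

Compound 4 `CC(C)=CCCC1=CC[C@@H](C(=O)N(C)O)[C@H](c2ccccc2)C1` has not yet been measured. From compound 3 it differs as hydroxy(methyl)amino in place of amino on a carbonyl carbon. Within the data shown here, no measured step covers this change: the single step in hand, a step that the two limits leave unreadable from compound 1 to compound 3, cannot be read. Compound 2 carries the same hydroxy(methyl)carbamoyl group and gives a readable value, which suggests a move out of the limit is possible, but its size cannot be taken from any step shown. The step from compound 3 to compound 4 is expected to be an at least 3.2-fold lower number from compound 3 to compound 4 (0.51 log units; beyond the scatter). Compound 4 is expected at 7000 nM, with a range from 1500 nM to 30000 nM.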

Compound 4, inhibition constant: 2300 nM
Beside the measured number, compound 4's estimate is 3.0-fold (0.48 log units) above it; low and high end bracket the measured number.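

In this assay, hydroxy(methyl)amino in place of amino on a carbonyl carbon gives an at least 10-fold lower number from compound 3 to compound 4 (1.00 log units; beyond the scatter), and the same group in place of (4-methoxyphenyl)amino gives an at least 10-fold lower number from compound 1 to compound 4 (1.00 log units; beyond the scatter), so both changes bring a readable number out of a limit and their true size may be larger still. The mirror-image pair gives a 1.1-fold higher number from compound 2 to compound 4 (0.04 log units; within the scatter), so inverting both stereocentres together shows no readable effect with this group on the shared core, a comparison that rests on this: the fact that compounds 2 and 4 differ only in the configuration as drawn. Among these four compounds, a readable number appears only with hydroxy(methyl)carbamoyl, while compounds 1 and 3 remain at a limit of the assay: the limit of > 23000 nM in this assay, at which 2 of the 4 values shown sit.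

The compounds shown leave open which part of hydroxy(methyl)amino matters, a question that a hydroxyamino or a methylamino group on the same carbonyl carbon could separate, and whether a carboxylic acid there would also give a readable number. They also leave open what inverting only one of the two stereocentres would do, since the pair shown inverts both.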